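The source may report more compounds than this note shows. Statements on the series, on what has been measured and on what is new or still open speak of the compounds shown alone.

In an in vivo ADME assay on the whole organism for pharmacokinetics, with Rattus norvegicus as the target (a higher number here means that a larger share of the oral dose reaches the circulation, a lower number that a smaller share of the oral dose reaches the circulation), compound 1 `CC(C)(C)Sc1c(CC(C)(C)C(=O)O)n(Cc2ccc(Cl)cc2)c2ccc(OCc3nc4ccccc4s3)cc12` gives 81% and compound 2 `CC(C)(C)Sc1c(CC(C)(C)C(=O)O)n(Cc2ccc(Cl)cc2)c2ccc(OCc3cccc(Cl)n3)cc12` gives 37%, so compound 2 holds the lower of the two numbers. Compound 3 `C[C@@H](COc1ccc2c(c1)c(SC(C)(C)C)c(CC(C)(C)C(=O)O)n2Cc1ccc(Cl)cc1)c1ccccn1` differs from compound 2 by 1-(pyridin-2-yl)ethyl in place of 6-chloropyridin-2-yl on a saturated chain carbon bound to an oxygen on an aromatic ring. For the measured compounds named here, the only measured step at this place, a number 44 percentage points lower from compound 1 to compound 2 (beyond the scatter), shows that a change here can move the number far, but it concerns a different exchange and gives no direction for this one. No step beyond the scatter is therefore expected, the estimated step being a number 8 percentage points higher from compound 2 to compound 3 (within the scatter). Compound 3 is estimated at 45%, within a range of 20% to 70%.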

Compound 3, oral bioavailability: 60%
Compound 3: the middle estimate sits 15 percentage points below what was measured; low and high end bracket the measured number.
By their numbers in this assay, from the lowest: compound 2; then compound 3; then compound 1.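

In this assay, 1-(pyridin-2-yl)ethyl in place of 6-chloropyridin-2-yl gives (a number 23 percentage points higher from compound 2 to compound 3 (beyond the scatter)), while 1-(pyridin-2-yl)ethyl in place of 1,3-benzothiazol-2-yl gives (a number 21 percentage points lower from compound 1 to compound 3 (beyond the scatter)). The three groups at this place therefore stand at three separate levels, and compound 2 and compound 3 differ even though each group carries one six-membered aromatic ring with 1 hetero atom. Nothing available explains either step. The compounds shown leave open what the opposite configuration of the stereocentre in 1-(pyridin-2-yl)ethyl would give. They also leave open how a quinolin-2-yl group would compare at this place.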